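Changing the Aryl Group: An Expectation for Compound 4

A few compounds are considered here, and "the series" means these few. Any claim that something is new, unique, unknown or untested is made for them only; others in the source may bear on it.

The measured compounds are:
- compound 1, `COC1=C(C)C(=O)/C(=C(O)/C=C/c2ccc(Br)cc2)C(=O)C1(C)C`, which in a functional assay on HUVEC cells (Homo sapiens) for cytotoxicity (on this read-out higher numbers stand for an effect only at larger amounts of compound and lower numbers for an effect already at smaller amounts), gives 3.6 ug/mL;
- compound 2, `COC1=C(C)C(=O)/C(=C(O)/C=C/c2ccccc2OC)C(=O)C1(C)C`, which in this assay gives 1.7 ug/mL;
- compound 3, `COC1=C(C)C(=O)/C(=C(O)/C=C/c2ccc(C)cc2)C(=O)C1(C)C`, which in this assay gives 2.4 ug/mL.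

Compound 2 has the lowest of the three numbers in this assay. Its nearest neighbour is compound 3, with a 1.4-fold higher number from compound 2 to compound 3 (0.15 log units; within the scatter), and its furthest is compound 1, with a 2.1-fold lower number from compound 1 to compound 2 (0.33 log units; beyond the scatter). The new compound 4, `COC1=C(C)C(=O)/C(=C(O)/C=C/c2cccs2)C(=O)C1(C)C`, differs from compound 2 as follows: thiophen-2-yl in place of 2-methoxyphenyl on a double-bonded chain carbon bound to a double-bonded chain carbon.

Among the compounds with values here, two measured steps bear on this change, since both swap the group on the same double-bonded chain carbon: from compound 1 to compound 2 the step was a 2.1-fold lower number from compound 1 to compound 2 (0.33 log units; beyond the scatter), and from compound 2 to compound 3 it was a 1.4-fold higher number from compound 2 to compound 3 (0.15 log units; within the scatter). Such swaps have so far moved the number only modestly, and in no consistent direction. The step to compound 4 is therefore expected to be small in this assay, most likely within the scatter and, if anything, toward a slightly higher number: a 1.3-fold higher number from compound 2 to compound 4 (0.11 log units; within the scatter). Compound 4 is estimated at 2.2 ug/mL, within a range from 1 ug/mL to 4.5 ug/mL.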

Compound 4, concentration for half-maximal effect: 2.5 ug/mL
The estimate for compound 4 lay 1.1-fold (0.06 log units) below the measured number; the measured number falls inside the stated range.
By their numbers in this assay, from the lowest: compounds 2, 3, 4 and 1 (each within the scatter of the next, the first and the last beyond it).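

In this assay, within the data shown here, thiophen-2-yl is the first group on this double-bonded chain carbon that is a five-membered aromatic ring with a hetero atom rather than a six-membered aromatic ring of carbon only, and each of its steps lies within the scatter (a 1.5-fold higher number from compound 2 to compound 4 (0.17 log units; within the scatter)) (a 1.0-fold higher number from compound 3 to compound 4 (0.02 log units; within the scatter)) (a 1.4-fold lower number from compound 1 to compound 4 (0.16 log units; within the scatter)). Compound 4 thus sits within the scatter of compound 1 and of compound 2, although those two stand beyond the scatter of each other. The data shown hold no measurement that would explain this result.

Going by these compounds, all four compounds carry an aromatic ring at this place, so it remains open whether an amine, a carboxylic acid or a longer chain there would stay within the same scatter. On these data alone, whether a pyridin-3-yl ring would fit with thiophen-2-yl also remains open.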